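Compound 3 to compound 4: acetyl on the aniline nitrogen

A few compounds are considered here, and "the series" means these few. Any claim that something is new, unique, unknown or untested is made for them only; others in the source may bear on it.

Values in a functional assay on HCC827 cells (Homo sapiens) for cytotoxicity, read by MTT assay, with a stated time of 72 h; on this read-out lower numbers stand for stronger inhibition and higher numbers for weaker inhibition:
- compound 1 `CN1CCN(c2ccc(Nc3ncc4nc(Nc5ccccc5)n(-c5ccccc5)c4n3)cc2)CC1`: 1.7 nM
- compound 2 `CC1CCN(c2ccc(Nc3ncc4nc(Nc5ccccc5)n(C5CCCC5)c4n3)cc2)CC1`: 32 nM
- compound 3 `OCCNc1ccc(Nc2ncc3nc(Nc4ccccc4)n(C4CCCC4)c3n2)cc1`: 2.8 nM

Compound 3 cannot be separated from compound 1 on these numbers and stands well under compound 2. Compound 4 `CC(=O)Nc1ccc(Nc2ncc3nc(Nc4ccccc4)n(C4CCCC4)c3n2)cc1` carries acetyl in place of 2-hydroxyethyl on a nitrogen on an aromatic ring. Among the compounds with values here, the only measured step touching this group is an 11-fold lower number from compound 2 to compound 3 (1.06 log units; beyond the scatter), a large one, which shows that the number can move strongly with this group. That single step gives no direction for the new change. In this assay the expected move is modest and toward a higher number, an estimated 2.5-fold higher number from compound 3 to compound 4 (0.40 log units; beyond the scatter). For compound 4 the expected value is 7 nM, with an estimated range of 1.5 nM to 35 nM.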

Compound 4, half-maximal inhibitory concentration: 0.47 nM
The estimate for compound 4 lay 15-fold (1.17 log units) above the measured number, and the stated range ends above it.
By their numbers in this assay, from the lowest: compound 4; then compounds 1 and 3 (each within the scatter of the next); then compound 2.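

In this assay, acetyl in place of 2-hydroxyethyl on a nitrogen on an aromatic ring gives a 6.0-fold lower number from compound 3 to compound 4 (0.78 log units; beyond the scatter) and shows that this nitrogen can carry an acetyl group with a lower number than any other compound here. Measured against the 4-methylpiperidin-1-yl group, acetamido gives a 68-fold lower number from compound 2 to compound 4 (1.83 log units; beyond the scatter) and so extends the earlier 11-fold lower number from compound 2 to compound 3 (1.06 log units; beyond the scatter). No evidence bearing on the reason for this change is available.

As far as these compounds go, whether the lower number is particular to acetyl remains open. Propionyl, methanesulfonyl or a longer acyl chain on this nitrogen could show how far it extends.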